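From 3-methylphenyl to 3,5-dimethylphenyl in an antiproliferative series

The source may report more compounds than this note shows. Statements on the series, on what has been measured and on what is new or still open speak of the compounds shown alone.

Of the compounds shown here, three with a shared core have been measured in a functional assay (Homo sapiens) for antiproliferative activity, read by sulforhodamine B assay, with a stated time of 48 h; a lower number here means a stronger inhibitor, a higher number a weaker inhibitor. Compound 1 (`O=C1NCCN1c1ccc(S(=O)(=O)Nc2ccc3[nH]ccc3c2)cc1`) gives 770 nM, compound 2 (`Cc1cccc(NS(=O)(=O)c2ccc(N3CCNC3=O)cc2)c1`) gives 290 nM, and compound 3 (`COc1cc(NS(=O)(=O)c2ccc(N3CCNC3=O)cc2)cc(OC)c1OC`) gives 58 nM. Compound 2 therefore holds the middle place, with the second highest number of the three and gaps to both others that lie beyond the scatter.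

Compound 4 (`Cc1cc(C)cc(NS(=O)(=O)c2ccc(N3CCNC3=O)cc2)c1`) has not yet been measured and differs from compound 2 in one place: methyl in place of hydrogen on an aromatic carbon. This puts methyl in place of hydrogen on an aromatic carbon, turning 3-methylphenyl into 3,5-dimethylphenyl. Within the data shown here, no two measured compounds differ in only one place, so the data give no direct measure of this change. Among the measured compounds shown here, the one loose guide is compound 3, which carries more groups on the corresponding ring and gives 58 nM. A small move towards a lower number in this assay is expected, possibly no larger than the scatter, and the estimated size is a 1.7-fold lower number from compound 2 to compound 4 (0.23 log units; within the scatter). For compound 4 the expected value is 170 nM, within an estimated range of 60 nM to 450 nM.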

Compound 4, half-maximal inhibitory concentration: 260 nM
For compound 4 the middle estimate is 1.5-fold (0.18 log units) below the measured one; the measured number falls inside the stated range.
By their numbers in this assay, from the lowest: compound 3; then compounds 4 and 2 (each within the scatter of the next); then compound 1.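

In this assay, among these compounds, methyl in place of hydrogen on this aromatic carbon gives a 1.1-fold lower number from compound 2 to compound 4 (0.05 log units; within the scatter) as the first direct reading of a single change. At this place, meta to a large group and meta to a methyl group, the added methyl therefore leaves compound 2 and compound 4 indistinguishable in this assay. No further measurement bearing on this result is available.

The compounds shown leave open whether a different group at this place, such as a hydroxyl, an amine or a carboxylic acid, would shift the number beyond the scatter. They also leave open which single changes connect compound 2 to compound 3, which differ in more than one place.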